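Fluorophenyl Amide Variant of a Triazolopyrimidine Adenosine Ligand

The source may hold more compounds than are shown below. What is called first, only, known or untested is meant among the compounds shown, and "the series" means these compounds.

Measured compounds:
Compound 1, `O=C(Nc1nc(-c2ccccc2)nc2c1nnn2Cc1ccccc1)c1ccccc1C(F)(F)F`: 550 nM
Compound 2, `O=C(Nc1nc(-c2ccccc2)nc2c1nnn2Cc1ccccc1)c1ccc(Cl)cc1`: 108 nM

Two amides built on a shared core have been measured in an assay (strain Wistar) for displacement of a labelled ligand from adenosine receptor A1 (Rattus norvegicus), read by scintillation counting; on this read-out lower numbers stand for stronger inhibition and higher numbers for weaker inhibition. Compound 1, `O=C(Nc1nc(-c2ccccc2)nc2c1nnn2Cc1ccccc1)c1ccccc1C(F)(F)F`, carries 2-(trifluoromethyl)phenyl on the carbonyl carbon and gives 550 nM. For the measured compounds named here, compound 2, `O=C(Nc1nc(-c2ccccc2)nc2c1nnn2Cc1ccccc1)c1ccc(Cl)cc1`, carries 4-chlorophenyl there and gives 108 nM, the lower of the two numbers; the only step known, a 5.1-fold lower number from compound 1 to compound 2 (0.71 log units; beyond the scatter), is a modest one.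

Compound 3, `O=C(Nc1nc(-c2ccccc2)nc2c1nnn2Cc1ccccc1)c1ccccc1F`, is not yet measured. It differs from compound 2 in one place: 2-fluorophenyl in place of 4-chlorophenyl on a carbonyl carbon. Going by the values given here, the one measured step that bears on this change is the one from compound 1 to compound 2, in which 4-chlorophenyl entered and a 2-(trifluoromethyl)phenyl group left. Compound 3 reverses the direction of that change in kind, replacing 4-chlorophenyl with a 2-fluorophenyl group, so a step back toward the number of compound 1 is expected, though fluorine is not trifluoromethyl and the size of the step is uncertain. The estimated step from compound 2 to compound 3 is a 2.8-fold higher number from compound 2 to compound 3 (0.44 log units; beyond the scatter). Compound 3 is therefore expected to give about 300 nM in this assay, with a plausible range from 100 nM to 900 nM.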

Compound 3, inhibition constant: 40 nM
Estimate against measurement, compound 3: 7.5-fold (0.88 log units) above, outside the stated range (below it).
By their numbers in this assay, from the lowest: compound 3; then compound 2; then compound 1.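

In this assay the 2-fluorophenyl group on the carbonyl carbon turns out better than the 4-chlorophenyl group, with a 2.7-fold lower number from compound 2 to compound 3 (0.43 log units; beyond the scatter), so the move away from 4-chlorophenyl does not lead back toward compound 1. The two groups named with a 2 now stand at opposite ends of the three compounds: with a 14-fold lower number from compound 1 to compound 3 (1.14 log units; beyond the scatter), fluoro in place of trifluoromethyl on an aromatic carbon is the largest change seen here, so carrying a group at this named place does not by itself go with a higher number, and what that group is matters a great deal. Nothing measured on these compounds explains why the numbers fall in this order.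

The step from compound 2 to compound 3 changes both the halogen and its place on the ring, and the compounds shown cannot separate the two. As far as these compounds go, it remains open how 4-fluorophenyl, 2-chlorophenyl or unsubstituted phenyl on the same carbonyl carbon would read, and whether 2-methoxyphenyl would fall nearer to compound 3 or to compound 1.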